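This account rests on a few compounds, and the source may have more. Where it says the series, first, only, none or still open, it means among the compounds named here.

Compound 1 `C/C(=C\c1ccc(NC(=O)Nc2ccc(Cl)c(C(F)(F)F)c2)cc1)C(=O)NC(C)c1ccccc1`, compound 2 `CNC(=O)/C(C)=C/c1ccc(NC(=O)Nc2ccc(Cl)c(C(F)(F)F)c2)cc1` and compound 3 `CNC(=O)/C=C(\C)c1ccc(NC(=O)Nc2ccc(Cl)c(C(F)(F)F)c2)cc1` share one core and were all tested in a functional assay on MX1 cells (Homo sapiens) for inhibition, read by MTT assay, with a stated time of 120 h; a lower number here means a stronger inhibitor, a higher number a weaker inhibitor. Compound 1 gives only a limit, > 50000 nM. Compound 2 also gives only a limit, > 50000 nM. Compound 3 likewise gives only a limit, > 50000 nM, so that (the limit of > 50000 nM in this assay, at which 3 of the 3 values shown sit). The change from compound 2 to compound 1 is 1-phenylethyl in place of methyl on an amide-type nitrogen, and its step is a step that the two limits leave unreadable from compound 2 to compound 1. The two cores differ as 1-methyl-2-(methylcarbamoyl)ethenyl in place of 2-(methylcarbamoyl)prop-1-en-1-yl on an aromatic carbon, with a step that the two limits leave unreadable from compound 2 to compound 3. Compound 4 `C/C(=C\C(=O)NC(C)c1ccccc1)c1ccc(NC(=O)Nc2ccc(Cl)c(C(F)(F)F)c2)cc1` is not yet measured; it differs from compound 3 by 1-phenylethyl in place of methyl on an amide-type nitrogen, the same change as that from compound 2 to compound 1, made at the same place. With every measured value sitting at a limit, compound 4 is expected to give 50000 nM, most likely again only a limit, which means an expected step of a number no higher from compound 3 to compound 4 (the limit leaves the size open).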

Compound 4, half-maximal inhibitory concentration: > 50000 nM
Compound 4: only a limit was reported; the forecaster's own chance of this, stated with the estimate: 85%; the middle value sits exactly at the limit.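

Going by these compounds alone, compound 4 gives only a limit, as compound 3 does, so no step between compound 3 and compound 4 can be read: the limit of > 50000 nM in this assay, at which 4 of the 4 values shown sit.

The compounds shown leave open what effect, if any, in this assay goes with 1-phenylethyl in place of methyl on an amide-type nitrogen.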